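Aryl sulfonamide series: trifluoromethoxy in place of methyl

The source may report more compounds than this note shows. Statements on the series, on what has been measured and on what is new or still open speak of the compounds shown alone.

Compound 1 `Cc1ccc(S(=O)(=O)N2C(=O)COC23C=CC(=O)C=C3)cc1` gives 110 nM in a functional assay on A549 cells (Homo sapiens) for inhibition, read by sulforhodamine B assay, with a stated time of 74 h; a higher number here means a weaker inhibitor, a lower number a stronger inhibitor. Compound 3 `O=C1C=CC2(C=C1)OCC(=O)N2S(=O)(=O)c1ccc(OC(F)(F)F)cc1` carries the change trifluoromethoxy in place of methyl on an aromatic carbon and gives 40 nM in this assay; the step of a 2.8-fold lower number from compound 1 to compound 3 (0.44 log units; beyond the scatter) is modest. Compound 2 `Cc1ccccc1S(=O)(=O)N1C(=O)COC12C=CC(=O)C=C2` differs from compound 1 by 2-methylphenyl in place of 4-methylphenyl on a sulfonyl sulfur. For compound 2 this assay reports only a limit, > 10000 nM, so the step of an at least 90-fold higher number from compound 1 to compound 2 (1.95 log units; beyond the scatter) is large and open-ended, with compound 2 sitting at the limit of > 10000 nM in this assay, at which 1 of the 3 values shown sits.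

Compound 4 `O=C1C=CC2(C=C1)OCC(=O)N2S(=O)(=O)c1ccccc1OC(F)(F)F` is unmeasured and differs from compound 2 by trifluoromethoxy in place of methyl on an aromatic carbon. This is the same kind of change as that from compound 1 to compound 3, but not the same: there the trifluoromethoxy sits para to a large group, here it sits ortho to a large group. The expectation for compound 4 rests on the measured change from compound 1 to compound 3, a 2.8-fold lower number from compound 1 to compound 3 (0.44 log units; beyond the scatter), applied to a starting point that is itself only a limit, so the expected step of an at least 1.2-fold lower number from compound 2 to compound 4 (0.09 log units; that floor lies within the scatter) is of similar modest size but uncertain in absolute terms. Compound 4 is therefore estimated at 8000 nM in this assay, within 2000 nM to 30000 nM.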

Compound 4, half-maximal inhibitory concentration: > 10000 nM
Compound 4: a limit, no number; the forecaster's own chance of this, stated with the estimate: 55%; middle value at least 1.2-fold (0.09 log units) away from the limit.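

Compound 2 and compound 4 both stand only as limits in this assay, and no step can be read from compound 2 to compound 4: the limit of > 10000 nM in this assay, at which 2 of the 4 values shown sit.

The compounds shown leave open whether trifluoromethoxy in place of methyl changes the read-out at all when it sits ortho to a large group, and how far apart compound 2 and compound 4 lie.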